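This account rests on a few compounds, and the source may have more. Where it says the series, first, only, none or still open, it means among the compounds named here.

Of the compounds shown here, three built on one shared core have been tested in an ADME assay on HEp-2 cells (Homo sapiens) for cytotoxicity, read by CCK-8 assay, with a stated time of 6 days; on this read-out lower numbers stand for higher toxicity in this test and higher numbers for lower toxicity in this test. Compound 1, `NCCNc1cc(N2CCN(c3ccccc3)CC2)nc2ccccc12`, gives 20800 nM in this assay. Compound 2, `CC(C)CC(=O)N1CCN(c2cc(NCCN)c3ccccc3n2)CC1`, reaches only a limit of this assay, > 100000 nM. Compound 3, `CC(=O)N1CCN(c2cc(NCCN)c3ccccc3n2)CC1`, likewise sits at a limit of this assay, > 100000 nM. Compound 3 therefore stands at the limit of > 100000 nM in this assay, at which 2 of the 3 values shown sit, where no number is read.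

The untested compound 4, `NCCNc1cc(N2CCN(c3ccc(Cl)cc3)CC2)nc2ccccc12`, differs from compound 3 in one place: 4-chlorophenyl in place of acetyl on an amine nitrogen in a ring. Among the compounds with values here, two measured steps bear on this change, both running the opposite way, from an aryl group to an acyl group on that ring nitrogen: an at least 4.8-fold higher number from compound 1 to compound 3 (0.68 log units; beyond the scatter), and in the same sense an at least 4.8-fold higher number from compound 1 to compound 2 (0.68 log units; beyond the scatter). Between the two acyl compounds, a step that the two limits leave unreadable from compound 2 to compound 3.

Because compound 1 gives 20800 nM with a phenyl on that nitrogen, compound 4 is expected to show an at least 6.6-fold lower number from compound 3 to compound 4 (0.82 log units; beyond the scatter), a drop in the number beyond the scatter. Compound 4 is therefore estimated at 15000 nM, within a range from 5000 nM to 50000 nM.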

Compound 4, half-maximal cytotoxic concentration: 6600 nM
Beside the measured number, compound 4's estimate is 2.3-fold (0.36 log units) above it, and the stated range covers the measured number.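

With a chloro in place of hydrogen on an aromatic carbon, this assay gives a 3.2-fold lower number from compound 1 to compound 4 (0.50 log units; beyond the scatter), which shows that the read-out responds to a change on the aryl group itself and not only to the swap between aryl and acyl groups on the amine nitrogen in the ring. The 4-chlorophenyl group extends the aryl-acyl contrast seen with compound 1, with an at least 15-fold lower number from compound 3 to compound 4 (1.18 log units; beyond the scatter) and an at least 15-fold lower number from compound 2 to compound 4 (1.18 log units; beyond the scatter). Both of these steps start from a limit and not from a number: the limit of > 100000 nM in this assay, at which 2 of the 4 values shown sit.

The compounds shown leave open whether a methoxy group or a nitrile in place of the chloro would move the number the same way. They also leave open how a longer acyl chain or a carboxylic acid on that ring nitrogen would read.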